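A few compounds are considered here, and "the series" means these few. Any claim that something is new, unique, unknown or untested is made for them only; others in the source may bear on it.

In a functional assay on MIA PaCa-2 cells (Homo sapiens) for inhibition, read by MTT assay, with a stated time of 3 days (on this read-out higher numbers stand for weaker inhibition and lower numbers for stronger inhibition), compound 2, whose structure is `CCN(CC)S(=O)(=O)c1ccc(S(=O)(=O)N2CCC[C@@H](C(=O)NC)C2)cc1`, reaches only a limit of the assay, namely > 10000 nM. Compound 3, with the structure `CCN(CC)S(=O)(=O)c1ccc(S(=O)(=O)N2CCC[C@@H](C(=O)N[C@H]3CCN(C(=O)OC(C)(C)C)C3)C2)cc1`, differs from it in one place: 1-(tert-butoxycarbonyl)pyrrolidin-3-yl in place of methyl on an amide-type nitrogen. For the measured compounds named here, the only measured step that touches this place is the one in which compound 1, with the structure `CCN(CC)S(=O)(=O)c1ccc(S(=O)(=O)N2CCC[C@@H](C(=O)N[C@@H]3CCN(C(=O)OC(C)(C)C)C3)C2)cc1`, carries the same group but in the opposite handedness on that stereocentre. In this assay compound 1 also reaches only a limit, > 10000 nM. The step from compound 1 to compound 2 is therefore a step that the two limits leave unreadable from compound 1 to compound 2, and its size stays hidden because of the limit of > 10000 nM in this assay, at which 2 of the 2 values shown sit. Nothing in these numbers shows that swapping methyl for the 1-(tert-butoxycarbonyl)pyrrolidin-3-yl group, in either handedness, brings a readable gain. The expectation is that compound 3 will again sit at the limit, with an estimated value of 15000 nM and a range from 5000 nM to 50000 nM. The step this estimate means, a step that the limit leaves unreadable from compound 2 to compound 3, is expected to be none beyond the scatter.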

Compound 3, half-maximal inhibitory concentration: > 10000 nM
Compound 3 ended at the assay's limit; the forecaster's own chance of this, stated with the estimate: 80%; the middle value lies beyond the limit too.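

No step among compound 1, compound 2 and compound 3 can be read in this assay, and the reason is the same for all of them: the limit of > 10000 nM in this assay, at which 3 of the 3 values shown sit.

The compounds shown leave open how far each one really lies beyond that limit, and so whether the 1-(tert-butoxycarbonyl)pyrrolidin-3-yl group or its handedness changes inhibition at all.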